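A few compounds are considered here, and "the series" means these few. Any claim that something is new, unique, unknown or untested is made for them only; others in the source may bear on it.

Measured compounds:
compound 1, `Cc1ccc(NC(=S)NC(=O)c2ccc(OCc3ccc(C(F)(F)F)cc3)cc2)cc1-c1nc2ccccc2[nH]1`, 72400 nM in a functional assay on SW-620 cells (Homo sapiens) for inhibition, read by MTT assay, with a stated time of 48 h; on this read-out higher numbers stand for weaker inhibition and lower numbers for stronger inhibition;
compound 2, `Cc1ccc(NC(=S)NC(=O)c2ccc(OCc3ccccc3Cl)cc2)cc1-c1nc2ccccc2[nH]1`, 57100 nM in this assay;
compound 3, `Cc1ccc(NC(=S)NC(=O)c2ccc(OCc3ccc(Cl)c(Cl)c3)cc2)cc1-c1nc2ccccc2[nH]1`, 30700 nM in this assay.

Compound 3 gives the lowest number of the three. One step is a 1.9-fold lower number from compound 2 to compound 3 (0.27 log units; within the scatter), so those two cannot be told apart, while the other step is a 2.4-fold lower number from compound 1 to compound 3 (0.37 log units; beyond the scatter), a modest but real difference. Compound 4, `Cc1ccc(NC(=S)NC(=O)c2ccc(OCc3ccc(Cl)cc3Cl)cc2)cc1-c1nc2ccccc2[nH]1`, carries the change (2,4-dichlorophenyl in place of 3,4-dichlorophenyl on a saturated chain carbon bound to an oxygen on an aromatic ring). Within the data shown here, the steps that bear on this change are those that also swapped the group on the same saturated chain carbon: a 1.3-fold lower number from compound 1 to compound 2 (0.10 log units; within the scatter), a 2.4-fold lower number from compound 1 to compound 3 (0.37 log units; beyond the scatter) and a 1.9-fold lower number from compound 2 to compound 3 (0.27 log units; within the scatter). Among the measured compounds shown here, all of them were small, and no earlier step moved the number a great deal. The expectation for compound 4 in this assay is therefore a step that stays close to compound 3, estimated as a 1.1-fold higher number from compound 3 to compound 4 (0.06 log units; within the scatter). Compound 4 is thus expected to give about 35000 nM, with a likely range from 15000 nM to 80000 nM.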

Compound 4, half-maximal inhibitory concentration: 57200 nM
Estimate against measurement, compound 4: 1.6-fold (0.21 log units) below; the measured number falls inside the stated range.
By their numbers in this assay, from the lowest: compounds 3, 2, 4 and 1 (each within the scatter of the next, the first and the last beyond it).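

In this assay, the swap to 2,4-dichlorophenyl from 3,4-dichlorophenyl keeps the same atoms and joins them differently, and it gives a 1.9-fold higher number from compound 3 to compound 4 (0.27 log units; within the scatter) and so no readable effect of where the chlorines sit. A new kind of step, chloro in place of hydrogen on an aromatic carbon, gives a 1.0-fold higher number from compound 2 to compound 4 (0.00 log units; within the scatter) and shows no readable effect of the added chlorine, while 2,4-dichlorophenyl in place of 4-(trifluoromethyl)phenyl gives a 1.3-fold lower number from compound 1 to compound 4 (0.10 log units; within the scatter) and is no clearer. Compound 4 therefore cannot be told apart from any of the other three compounds, and no measurement on hand accounts for these small steps.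

Every group shown at this position is a halogen-bearing or trifluoromethyl-bearing phenyl ring. As far as these compounds go, how an amine, a carboxylic acid or a longer chain on that ring would read in this assay remains open.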